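Removing the Trifluoromethoxy Group from the Anilino Substituent

The source may hold more compounds than are shown below. What is called first, only, known or untested is meant among the compounds shown, and "the series" means these compounds.

Measured in a functional assay on HepG2 cells (Homo sapiens) for antiproliferative activity, read by CCK-8 assay, with a stated time of 72 h, tested at 8 uM; a lower number here means a weaker effect, a higher number a stronger effect of the compound at the concentration tested:
- compound 1 `CC1CCN(c2nc(Cl)nc3c2ncn3Cc2ccc(/C=C/C(=O)Nc3ccccc3N)cc2)CC1` gives 32.2%
- compound 2 `Cc1ccc(Nc2nc(Cl)nc3c2ncn3Cc2ccc(/C=C/C(=O)Nc3ccccc3N)cc2)cc1` gives 43%
- compound 3 `Nc1ccccc1NC(=O)/C=C/c1ccc(Cn2cnc3c(Nc4cccc(OC(F)(F)F)c4)nc(Cl)nc32)cc1` gives 37.6%

Compound 3 stands second highest of these three numbers. Its nearest neighbour is compound 1, and the step of a number 5.4 percentage points higher from compound 1 to compound 3 (within the scatter) lies within the scatter; its furthest is compound 2, and the step of a number 5.4 percentage points lower from compound 2 to compound 3 (within the scatter) likewise lies within the scatter. Going by the values given here, the only step among the three that reaches beyond the scatter is a number 10.8 percentage points higher from compound 1 to compound 2 (beyond the scatter), a modest one, where a (4-methylphenyl)amino group replaces 4-methylpiperidin-1-yl on the shared core.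

Compound 4 `Nc1ccccc1NC(=O)/C=C/c1ccc(Cn2cnc3c(Nc4ccccc4)nc(Cl)nc32)cc1` is not yet measured. It differs from compound 3 in one place: hydrogen in place of trifluoromethoxy on an aromatic carbon. Among the compounds with values here, the step that bears most on this is the one from compound 2 to compound 3, where one aryl group on the ring nitrogen was exchanged for another and the number stayed within the scatter. On that basis, a further change of the aryl group at the same place is expected to move the read-out in this assay little, with no step beyond the scatter in either direction; the expected step is a number 0.4 percentage points higher from compound 3 to compound 4 (within the scatter). Compound 4 is therefore estimated at 38%, with a range from 26% to 50%.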

Compound 4, a percentage reported as inhibition, at one concentration (the size of the read-out at that concentration, not a potency): 41.9%
Estimate against measurement, compound 4: 3.9 percentage points below; measured number inside the range.
By their numbers in this assay, from the lowest: compounds 1, 3, 4 and 2 (each within the scatter of the next, the first and the last beyond it).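

In this assay, replacing trifluoromethoxy with hydrogen gives a number 4.3 percentage points higher from compound 3 to compound 4 (within the scatter) and so shows that this group of 5 heavy atoms is not needed at this place to keep the read-out. Replacing methyl with hydrogen gives a number 1.1 percentage points lower from compound 2 to compound 4 (within the scatter) as well, so compounds 2, 3 and 4, with methyl, trifluoromethoxy or hydrogen on the anilino ring, cannot be told apart in this read-out. The comparison with the 4-methylpiperidin-1-yl group is also more guarded than compound 2 alone suggested: the plain anilino group gives a number 9.7 percentage points higher from compound 1 to compound 4 (within the scatter) while the earlier change gave a number 10.8 percentage points higher from compound 1 to compound 2 (beyond the scatter) and so only the (4-methylphenyl)amino group clears the scatter against compound 1, by a modest step.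

Still open, going by these compounds, is whether an amine or a carboxylic acid on the anilino ring, or a longer chain in its place, would move the read-out beyond the scatter. No measurement at hand explains why these steps are so small.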